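The compounds below may be only part of what the source reports. "The series", "measured", "known", "first", "only" and "open" are said of these compounds alone.

Working notes on the sulfonyl anilide series.

Within the data shown here, compound 1 `CC(O)(C(=O)Nc1ccc(S(=O)(=O)c2ccccc2F)cc1)C(F)(F)F` gives 1300 nM in a functional assay (Cavia porcellus) with sulfonylurea receptors; K-ATP channels (Homo sapiens) as the target (on this read-out higher numbers stand for weaker inhibition and lower numbers for stronger inhibition), and is the only member with a number rather than a limit. Compound 2 `CC(O)(C(=O)Nc1ccc(S(=O)(=O)c2ccccc2)c(C(F)(F)F)c1)C(F)(F)F` reaches only the limit > 30000 nM in this assay. Compound 3 `CC(O)(C(=O)Nc1ccc(S(=O)(=O)N(c2ccccc2)c2ccccc2)cc1)C(F)(F)F` likewise stops at the limit > 30000 nM in this assay. Two of three values thus sit at the limit of > 30000 nM in this assay, at which 2 of the 3 values shown sit, so compound 1 is the one fixed point of the set.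

Compound 4 `CC(O)(C(=O)Nc1ccc(S(=O)(=O)c2cnccn2)cc1)C(F)(F)F` is not yet measured. It differs from compound 1 by pyrazin-2-yl in place of 2-fluorophenyl on a sulfonyl sulfur. Among the measured compounds shown here, no measured pair isolates such a swap, so the expected step from compound 1 to compound 4 is set modest, toward weaker inhibition, at a 1.9-fold higher number from compound 1 to compound 4 (0.28 log units; within the scatter). Compound 4 is expected to give about 2500 nM, with a plausible range from 600 nM to 12000 nM.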

Compound 4, half-maximal inhibitory concentration: 12000 nM
Estimate against measurement, compound 4: 4.8-fold (0.68 log units) below; the measured number falls inside the stated range.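

On a sulfonyl sulfur whose other neighbour is an aromatic carbon, the ring is not interchangeable in this assay: pyrazin-2-yl in place of 2-fluorophenyl gives a 9.2-fold higher number from compound 1 to compound 4 (0.97 log units; beyond the scatter). Among these compounds, this is the only step that can be read, and compound 4 still gives a number rather than a limit. Nothing shown accounts for the size of this step.

The swap removes the fluorine and brings in two ring nitrogens at once, so their shares remain unseparated. A pyridin-2-yl group on the same sulfur would bear on that question.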